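The compounds below may be only part of what the source reports. "The series", "measured", "known", "first", "only" and "open" are said of these compounds alone.

In a functional assay on NCI-H23 cells (Homo sapiens) for antiproliferative activity, read by sulforhodamine B assay (on this read-out lower numbers stand for stronger inhibition of growth and higher numbers for weaker inhibition of growth), two compounds have been measured so far:

Compound 1 `CCCCCCOc1cccc(O)c1C(=O)/C=C/c1ccc(O)cc1` gives > 30000 nM as a limit of the assay.
Compound 2 `O=C(/C=C/c1ccc(O)cc1)c1c(O)cccc1OCC1CCCC1` gives 3160 nM as a measured number.

Going by the values given here, compound 2 holds the only true number here, since the one other value is a limit. The next compound is compound 3 `CC(C)COc1cccc(O)c1C(=O)/C=C/c1ccc(O)cc1`, with isopropyl in place of cyclopentyl on a saturated chain carbon bound to an oxygen on an aromatic ring. Among the compounds with values here, one measured step bears on this change, namely an at least 9.4-fold lower number from compound 1 to compound 2 (0.97 log units; beyond the scatter) with cyclopentyl in place of pentyl at that same place. The change now runs partly the other way. The ring leaves and an open group enters, though it is not the pentyl of that step. A single step gives the direction only loosely, so a modest rise in the number is expected in this assay rather than a step of full size. The expected change is a 2.5-fold higher number from compound 2 to compound 3 (0.40 log units; beyond the scatter) towards weaker inhibition of growth. Compound 3 is estimated at 8000 nM with a range from 2500 nM to 30000 nM expected.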

Compound 3, concentration for 50% growth inhibition: 3220 nM
Estimate against measurement, compound 3: 2.5-fold (0.40 log units) above; measured number inside the range.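

In this assay, the ring of compound 2 turns out not to be required at this place, on a saturated chain carbon bound to an oxygen on an aromatic ring: the step is a 1.0-fold higher number from compound 2 to compound 3 (0.01 log units; within the scatter) and, with isopropyl in place of cyclopentyl, the two groups cannot be told apart here. The pentyl of compound 1 is the group that stands apart, with an at least 9.3-fold lower number from compound 1 to compound 3 (0.96 log units; beyond the scatter) for isopropyl in place of pentyl, so an open group can serve as well as the ring, and the step seen earlier did not depend on a ring being present. Going by these compounds, compound 1 gives > 30000 nM, which is a limit and not a number, so the full size of both steps from it stays unknown: the limit of > 30000 nM in this assay, at which 1 of the 3 values shown sits.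

On these data alone, whether a butyl or a straight propyl at this place would stay level with compound 2 and compound 3 or fall in with compound 1 remains open. Also open, as far as these compounds go, is what a cyclopropyl, a tert-butyl or a chain ending in an amine or a carboxylic acid would give here.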